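A few compounds are considered here, and "the series" means these few. Any claim that something is new, unique, unknown or untested is made for them only; others in the source may bear on it.

Compound 1 `CCCOc1ccc2[nH]c(-c3ccc(OC)cc3)c(C3=C(Br)C(=O)NC3=O)c2c1` and compound 2 `CCCCCOc1ccc2[nH]c(-c3ccc(OC)cc3)c(C3=C(Br)C(=O)NC3=O)c2c1` share one core, and compound 3 `CCc1ccc2[nH]c(-c3cccc(OC)c3)c(C3=C(Br)C(=O)NC3=O)c2c1` and compound 4 `CCCCc1ccc2[nH]c(-c3cccc(OC)c3)c(C3=C(Br)C(=O)NC3=O)c2c1` share another; the difference between the two cores is not broken down here. In a physicochemical assay for lipophilicity (on this read-out lower numbers stand for lower lipophilicity and higher numbers for higher lipophilicity), compound 1 gives 3.12, and compound 2 gives 3.77. The change between them, (ethyl in place of hydrogen on a saturated chain carbon, three bonds along the chain from an oxygen on an aromatic ring), produces a step of a number 0.65 log units higher from compound 1 to compound 2 (beyond the scatter). Compound 3 gives 3.35 in this assay, a number within the scatter of compound 1 and beyond the scatter below compound 2. Compound 4 differs from compound 3 by ethyl in place of hydrogen on a saturated chain carbon, two bonds along the chain from an aromatic carbon. Among the measured compounds shown here, this is the same kind of change as the one from compound 1 to compound 2, though the place differs: there the ethyl enters three bonds along the chain from an oxygen on an aromatic ring, here two bonds along the chain from an aromatic carbon. For the measured compounds named here, compound 4 is therefore expected to move by a number 0.65 log units higher from compound 3 to compound 4 (beyond the scatter) in this assay, a step of similar size, because a number 0.65 log units higher from compound 1 to compound 2 (beyond the scatter) is the only measured step of this kind. For compound 4 the expected value in this assay is 4, likely between 3.7 and 4.3.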

Compound 4, partition coefficient: 3.81
The estimate for compound 4 lay 0.19 log units above the measured number; low and high end bracket the measured number.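

In this assay the new step reads a number 0.46 log units higher from compound 3 to compound 4 (beyond the scatter), set against a number 0.65 log units higher from compound 1 to compound 2 (beyond the scatter) on the other core, so ethyl in place of hydrogen raised the number on both cores and the direction of the change carried across. Among the compounds shown here, this does not show that the size of the step is fixed: there are only two pairs, and core and place differ together, three bonds along the chain from an oxygen on an aromatic ring in one and two bonds along the chain from an aromatic carbon in the other, so any difference between the steps cannot be assigned to either, and nothing here extends the result to a further core. Nothing available explains the size of either step.

The compounds shown leave open whether the step would hold if a longer chain took the place of ethyl on either core. They also leave open what an amine or a carboxylic acid in that same place would give.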